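Aryl ketone swap on a pyrazole chalcone: compound 4 expected

The source may report more compounds than this note shows. Statements on the series, on what has been measured and on what is new or still open speak of the compounds shown alone.

Measured compounds:
compound 1 `COc1ccc(C(=O)/C=C/c2cn(-c3ccccc3)nc2-c2ccsc2)c(OC)c1OC` gives 7400 nM
compound 2 `COc1ccc(C(=O)/C=C/c2cn(-c3ccccc3)nc2-c2ccsc2)cc1OC` gives 2800 nM
compound 3 `O=C(/C=C/c1cn(-c2ccccc2)nc1-c1cccnc1)c1ccccn1` gives 4200 nM

Compound 3 stands second highest of the three numbers in a functional assay on MCF7 cells (Homo sapiens) for inhibition, read by sulforhodamine B assay, with a stated time of 72 h; on this read-out lower numbers stand for stronger inhibition and higher numbers for weaker inhibition. Its nearest neighbour is compound 2, and the gap between them lies within the scatter; compound 1 is furthest away, yet that gap too lies within the scatter. Compound 4 `COc1ccc(C(=O)/C=C/c2cn(-c3ccccc3)nc2-c2cccnc2)c(OC)c1` has not yet been measured in this assay. It differs from compound 3 by 2,4-dimethoxyphenyl in place of pyridin-2-yl on a carbonyl carbon.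

Going by the values given here, only one measured step bears on this change, and only loosely: a 2.6-fold lower number from compound 1 to compound 2 (0.42 log units; beyond the scatter), which concerns the number of methoxy groups on the aryl ketone rather than the exchange of a pyridine for a benzene ring. Compound 4 carries the same count of methoxy groups as compound 2, whose number in this assay is 2800 nM. Against that background compound 3 at 4200 nM is close by, so no step beyond the scatter is expected.

Compound 4 is therefore estimated at 3200 nM, with a range of 1100 nM to 9500 nM, which means an expected step of a 1.3-fold lower number from compound 3 to compound 4 (0.12 log units; within the scatter).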

Compound 4, half-maximal inhibitory concentration: 2300 nM
For compound 4 the middle estimate is 1.4-fold (0.14 log units) above the measured one; the range from low to high includes it.
By their numbers in this assay, from the lowest: compounds 4, 2, 3 and 1 (each within the scatter of the next, the first and the last beyond it).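

In this assay, replacing pyridin-2-yl with 2,4-dimethoxyphenyl on the carbonyl carbon gives a 1.8-fold lower number from compound 3 to compound 4 (0.26 log units; within the scatter). Going by these compounds alone, the earlier step, a 2.6-fold lower number from compound 1 to compound 2 (0.42 log units; beyond the scatter), concerned only a single methoxy group on the aryl ketone, whereas this one exchanges the whole ring: a six-membered aromatic ring with one hetero atom leaves, a carbon-only ring with two methoxy groups enters, and the read-out stays within the scatter. The position therefore tolerates this larger exchange in this assay, but no supporting data are available to explain the result.

The compounds shown leave open how this position would respond to an aryl ring carrying an amine or a carboxylic acid. They also leave open what each methoxy group of the 2,4-dimethoxyphenyl group contributes on its own.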